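This account rests on a few compounds, and the source may have more. Where it says the series, first, only, none or still open, it means among the compounds named here.

In an in vitro ADME assay on microsomes (Rattus norvegicus) for metabolic stability (on this read-out lower numbers stand for slow clearance and higher numbers for fast clearance), compound 1 (`O=C(CN1CC[C@@H](NC(=O)c2ccc(Cl)s2)C1)Nc1ccc(-n2ccccc2=O)cc1F`) gives 79.2 mL.min-1.g-1 and stands at the upper end of the three measured compounds, a place it shares with compound 2. Compound 2 (`CCO[C@H]1CN(CC(=O)Nc2ccc(-n3ccccc3=O)cc2F)C[C@@H]1NC(=O)c1ccc(Cl)s1`) carries ethoxy in place of hydrogen on a saturated ring carbon and gives 68.3 mL.min-1.g-1 in this read-out. That change brings a 1.2-fold lower number from compound 1 to compound 2 (0.06 log units; within the scatter) and so tells little. Compound 3 (`O=C(CN1C[C@H](CO)[C@@H](NC(=O)c2ccc(Cl)s2)C1)Nc1ccc(-n2ccccc2=O)cc1F`) carries hydroxymethyl in place of hydrogen on a saturated ring carbon and gives 35.4 mL.min-1.g-1 in the same read-out. Within the data shown here, that change brings a 2.2-fold lower number from compound 1 to compound 3 (0.35 log units; beyond the scatter) and is the closest precedent. The change to compound 4 (`O=C(CN1C[C@H](NC(=O)c2ccc(Cl)s2)C[C@H]1CO)Nc1ccc(-n2ccccc2=O)cc1F`), not yet measured, is hydroxymethyl in place of hydrogen on a saturated ring carbon and puts hydroxymethyl in place of hydrogen next to the ring nitrogen. Among the measured compounds shown here, the group is the same as in compound 3, but no measured compound carries it at this place, so a similar or somewhat smaller step towards a lower number is expected. The expected step is a 1.8-fold lower number from compound 1 to compound 4 (0.25 log units; within the scatter) on this reasoning. Compound 4 is estimated to give about 45 mL.min-1.g-1 with an expected range of 22 mL.min-1.g-1 to 85 mL.min-1.g-1 in this assay once measured.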

Compound 4, intrinsic clearance in microsomes: 17.6 mL.min-1.g-1
Estimate against measurement, compound 4: 2.6-fold (0.41 log units) above; the measured number lies below the stated range.
By their numbers in this assay, from the lowest: compounds 4, 3, 2 and 1 (each within the scatter of the next, the first and the last beyond it).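

In this assay, hydroxymethyl on a saturated ring carbon, next to the ring nitrogen, gives a 4.5-fold lower number from compound 1 to compound 4 (0.65 log units; beyond the scatter), so this position also allows a step beyond the scatter, which compound 3 had shown only for its own place. Compound 4 at 17.6 mL.min-1.g-1 and compound 3 at 35.4 mL.min-1.g-1 lie within the scatter of each other, so these numbers do not separate the two places of the group. Nothing measured here explains why the number falls at this position.

On these data alone, it stays open whether the hydroxyl end of the group is needed, which a plain methyl or a methoxymethyl group at this place would test. A longer chain such as hydroxyethyl, or an amine such as aminomethyl, would show how far the step depends on the group's length and end.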